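This account rests on a few compounds, and the source may have more. Where it says the series, first, only, none or still open, it means among the compounds named here.

Three compounds share one core and differ only in the group on an aromatic carbon of the six-membered aromatic ring with one nitrogen. In a functional assay on CHO-K1 cells for antagonist activity at transient receptor potential cation channel subfamily V member 1 (Homo sapiens), read by FLIPR (a lower number here means a stronger inhibitor, a higher number a weaker inhibitor), compound 1 `CC(C(=O)NCc1ccc(C(F)(F)F)nc1Nc1ccccc1)c1ccc(NS(C)(=O)=O)c(F)c1` gives 59.6 nM, compound 2 `Cc1ccc(Nc2nc(C(F)(F)F)ccc2CNC(=O)C(C)c2ccc(NS(C)(=O)=O)c(F)c2)cc1C` gives 39.3 nM, and compound 3 `CCCCN(C)c1nc(C(F)(F)F)ccc1CNC(=O)C(C)c1ccc(NS(C)(=O)=O)c(F)c1` gives 0.8 nM, the lowest of the three numbers. The steps of a 75-fold lower number from compound 1 to compound 3 (1.87 log units; beyond the scatter) and a 49-fold lower number from compound 2 to compound 3 (1.69 log units; beyond the scatter) show that a dialkylamino group at this spot gives far lower numbers than an anilino group. Compound 4 `CC(C(=O)NCc1ccc(C(F)(F)F)nc1N1CCCCC1C)c1ccc(NS(C)(=O)=O)c(F)c1` carries 2-methylpiperidin-1-yl in place of butyl(methyl)amino on an aromatic carbon. Among the measured compounds shown here, it keeps a dialkylamino group, so those two large steps point to it staying in the same class; no measured pair tests closing the chain into a ring. The step of a 1.9-fold higher number from compound 3 to compound 4 (0.27 log units; within the scatter) in this assay is therefore expected to be small. Compound 4 is estimated at 1.5 nM, with a range from 0.4 nM to 6 nM.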

Compound 4, inhibition constant: 2.9 nM
Compound 4: middle estimate off by 1.9-fold (0.29 log units), on the low side, and the stated range covers the measured number.
By their numbers in this assay, from the lowest: compound 3; then compound 4; then compounds 2 and 1 (each within the scatter of the next).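

In this assay, among the compounds shown here, 2-methylpiperidin-1-yl is the first group here that closes the butyl(methyl)amino chain into a ring, and the closure raises the number modestly (a 3.6-fold higher number from compound 3 to compound 4 (0.56 log units; beyond the scatter)). The ring still keeps a large lead over both anilino-type groups (a 14-fold lower number from compound 2 to compound 4 (1.13 log units; beyond the scatter); a 21-fold lower number from compound 1 to compound 4 (1.31 log units; beyond the scatter)), so the advantage of dialkylamino groups over these groups also holds for this ring. Nothing available explains why the ring gives a higher number than the open chain.

On these data alone, it remains open what the ring methyl contributes on its own: plain piperidin-1-yl or morpholin-4-yl could separate the effect of the ring from that of the methyl.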